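A few compounds are considered here, and "the series" means these few. Any claim that something is new, unique, unknown or untested is made for them only; others in the source may bear on it.

Measured so far in an ADME assay (liver) for metabolic stability, with Liver microsome (Rattus norvegicus) as the target, read by LC-MS, using microsomes and NADPH, with stated times of 5 min and 60 min, tested at 4 uM (a higher number here means that more of the compound is left, a lower number that less of the compound is left), for each compound:
- compound 1 `Cc1c(OCCCCOc2ccc(C(=O)O)cc2Cl)ccc(C(=O)CC2CCCC2)c1O` gives 21%
- compound 2 `Cc1c(OCCCCOc2cccc(C(=O)O)c2)ccc(C(=O)CC(C)C)c1C` gives 29%
- compound 3 `Cc1c(OCCCCOc2ccc(C(=O)O)cc2Cl)ccc(C(=O)CC(C)C)c1O` gives 61%

Compound 1 at 21% sits within the scatter of compound 2 at 29%. Compound 3 gives 61% on the same scale, and the gap between compound 1 and compound 3 is well beyond the scatter.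

The next compound is compound 4 `Cc1ccc(C(=O)O)cc1OCCCCOc1ccc(C(=O)CC2CCCC2)c(O)c1C` with the change 5-carboxy-2-methylphenyl in place of 4-carboxy-2-chlorophenyl on an oxygen on a saturated carbon in the structure of compound 1. In words, 5-carboxy-2-methylphenyl stands in place of 4-carboxy-2-chlorophenyl on an oxygen on a saturated carbon.

Among the measured compounds shown here, the only measured single-place step is a number 40 percentage points higher from compound 1 to compound 3 (beyond the scatter) and it is large. It exchanges the cyclopentyl, which compound 4 keeps, so it says nothing directly about this change. For the measured compounds named here, no measured step isolates the group exchanged here.

With the cyclopentyl kept, no change beyond the scatter is expected in this assay and the expected result is a number 1 percentage points lower from compound 1 to compound 4 (within the scatter) as the estimated step.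

For compound 4 the estimate is 20% within an expected range from 8% to 38% as its ends.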

Compound 4, percent of the compound remaining: 9%
Estimate against measurement, compound 4: 11 percentage points above; measured number inside the range.
By their numbers in this assay, from the lowest: compound 4; then compounds 1 and 2 (each within the scatter of the next); then compound 3.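

In this assay, the group on the oxygen on a saturated carbon also affects the read-out: a number 12 percentage points lower from compound 1 to compound 4 (beyond the scatter), with 5-carboxy-2-methylphenyl in place of 4-carboxy-2-chlorophenyl. The earlier single-place step exchanged the cyclopentyl, whereas here the cyclopentyl is kept, so this exchange alone gives a modest step beyond the scatter. Nothing at hand gives the cause of this step.

Going by these compounds, the exchange replaces chlorine with methyl and changes the numbering of the carboxy group at once, so it remains open which of the two carries the step, and whether it would hold with the isopropyl of compound 3. Also open, on these data alone, is how a primary amide in place of the carboxylic acid would read in this assay.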